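The compounds below may be only part of what the source reports. "The series", "measured", "known", "first", "only" and "open" are said of these compounds alone.

Working notes on the series in an ADME assay on HEK293 cells (Homo sapiens) for cytotoxicity, read by fluorescence and resazurin assay, with a stated time of 24 h; on this read-out lower numbers stand for higher toxicity in this test and higher numbers for lower toxicity in this test: compound 1 `O=S1(=O)C=C(Sc2nnc(-c3cccnc3)o2)c2ccccc21` gives 4000 nM. Compound 2 `O=S1(=O)C=C(Sc2nnc(C3CCCCC3)o2)c2ccccc21` gives 3000 nM, so the two numbers stand level within the scatter. The next change leads to compound 3 `Nc1ccc(-c2nnc(SC3=CS(=O)(=O)c4ccccc43)o2)cc1`, with 4-aminophenyl in place of cyclohexyl on an aromatic carbon of the five-membered aromatic ring with 2 nitrogen and 1 oxygen: 4-aminophenyl in place of cyclohexyl on an aromatic carbon. Among the compounds with values here, one measured step bears on this change: a 1.3-fold lower number from compound 1 to compound 2 (0.12 log units; within the scatter), with cyclohexyl in place of pyridin-3-yl, also on an aromatic carbon. Within the data shown here, that single pair is thin evidence, and no compound carrying 4-aminophenyl has yet been measured. No change beyond the scatter is therefore expected in this assay. The expected step is a 1.2-fold higher number from compound 2 to compound 3 (0.07 log units; within the scatter). Compound 3 is estimated at 3500 nM, with an expected range from 1300 nM to 9000 nM.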

Compound 3, half-maximal cytotoxic concentration: 4000 nM
Beside the measured number, compound 3's estimate is 1.1-fold (0.06 log units) below it; low and high end bracket the measured number.
By their numbers in this assay, from the lowest: compounds 2, 1 and 3 (each within the scatter of the next).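

In this assay, 4-aminophenyl gives a 1.3-fold higher number from compound 2 to compound 3 (0.12 log units; within the scatter) and no change at the digits printed from compound 1 to compound 3 (within the scatter) so neither step separates it from the earlier groups. This aromatic carbon next to the ring oxygen now carries three different groups at one level within the scatter: a non-aromatic carbon ring in cyclohexyl, a ring with nitrogen in pyridin-3-yl, and a carbon aromatic ring in 4-aminophenyl. The hydrogen-bond donor and acceptor that enter with 4-aminophenyl, absent from cyclohexyl, come with no step beyond the scatter in this small set.

As far as these compounds go, whether a carboxylic acid, a small methyl or a longer alkyl chain at this carbon would stay level with these three remains open. Nothing on hand gives a reason for this level reading.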